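Methyl in Place of Hydrogen on the Ring Amine Chain

A few compounds are considered here, and "the series" means these few. Any claim that something is new, unique, unknown or untested is made for them only; others in the source may bear on it.

Measured compounds:
compound 1 `CC(C)CN1CCC(c2ccc3c(c2)oc(=O)n3C(=O)NCCCCc2ccccc2)CC1` — 120 nM
compound 2 `CN1CCC(c2ccc3c(c2)oc(=O)n3C(=O)NCCCCc2ccccc2)CC1` — 129 nM

In an assay on HEK293 cells for inhibition of acid ceramidase (Homo sapiens), read by fluorescence, with stated times of 10 min and 3 h (a higher number here means a weaker inhibitor, a lower number a stronger inhibitor), compound 1 gives 120 nM and compound 2 gives 129 nM. Among the compounds with values here, compound 2 holds the highest of the two numbers, but its only neighbour lies within the scatter: the step of a 1.1-fold higher number from compound 1 to compound 2 (0.03 log units; within the scatter) shows that removing a whole isopropyl from the chain carbon on the ring amine nitrogen left the number essentially unchanged.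

Compound 3 `CCN1CCC(c2ccc3c(c2)oc(=O)n3C(=O)NCCCCc2ccccc2)CC1` differs from compound 2 by methyl in place of hydrogen on a saturated chain carbon bound to an amine nitrogen in a ring. Within the data shown here, the one measured step that bears on this change, a 1.1-fold higher number from compound 1 to compound 2 (0.03 log units; within the scatter), was flat, so adding back a single carbon at the same place is expected to give no step beyond the scatter in this assay, in either direction. The expected step is therefore a 1.0-fold lower number from compound 2 to compound 3 (0.01 log units; within the scatter). Compound 3 is estimated at 125 nM, within a range from 60 nM to 260 nM.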

Compound 3, half-maximal inhibitory concentration: 92 nM
Compound 3: middle estimate off by 1.4-fold (0.13 log units), on the high side, and the stated range covers the measured number.
By their numbers in this assay, from the lowest: compounds 3, 1 and 2 (each within the scatter of the next).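

In this assay the new compound gives the position a third point: adding the methyl gives a 1.4-fold lower number from compound 2 to compound 3 (0.15 log units; within the scatter) and the direct exchange of isopropyl for methyl on the same chain carbon gives a 1.3-fold lower number from compound 1 to compound 3 (0.12 log units; within the scatter). Both steps stay inside the scatter, so the 1-methylpiperidin-4-yl of compound 2, the 1-ethylpiperidin-4-yl of compound 3 and the isopropyl-bearing chain of compound 1 cannot be told apart here, and the flat result of the first pair now holds across all three compounds. Nothing measured here offers an explanation for this flatness.

The compounds shown leave open whether the number would stay as flat with a phenyl ring on this chain carbon, a carboxylic acid at the end of a longer chain, or only hydrogen on the ring amine nitrogen. They also leave open whether this flatness would hold if the butyl chain ending in phenyl on the urea were changed.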